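Methoxy for fluoro on the aryl ether of compound 2

The source may report more compounds than this note shows. Statements on the series, on what has been measured and on what is new or still open speak of the compounds shown alone.

Two compounds of the series have a reading in an ADME assay on microsomes from liver (Mus musculus) for metabolic stability, read by LC-MS, with a stated time of 30 min, tested at 1 ug/mL; a lower number here means that less of the compound is left, a higher number that more of the compound is left. Compound 1 `COc1ccc(Oc2ccc(N3CC(=O)N([C@@H](CC4CCN(C(=O)C(C)C)CC4)c4nc5ccc(C)cc5n4C)C3=O)cc2)cc1` gives 2.4%. For the measured compounds named here, compound 2 `Cc1ccc2nc([C@H](CC3CCN(C(=O)C(C)C)CC3)N3C(=O)CN(c4ccc(Oc5ccc(F)cc5)cc4)C3=O)n(C3CC3)c2c1` gives 43%, the higher of the two values, and the gap to compound 1 lies beyond the scatter; the two structures differ in more than one place, so no single-change step connects them. Compound 3 `COc1ccc(Oc2ccc(N3CC(=O)N([C@@H](CC4CCN(C(=O)C(C)C)CC4)c4nc5ccc(C)cc5n4C4CC4)C3=O)cc2)cc1` has not been measured in this assay . It differs from compound 2 by methoxy in place of fluoro on an aromatic carbon. Going by the values given here, the only other compound carrying a methoxy at that position is compound 1, which gives 2.4%, but it also differs elsewhere, so this is no guide on its own. The step from compound 2 to compound 3 is expected to go downward, at a size of a number 21 percentage points lower from compound 2 to compound 3 (beyond the scatter) in this assay . For compound 3 the estimate is 22%, with a range from 5% to 45%.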

Compound 3, percent of the compound remaining: 22.8%
Compound 3: middle estimate off by 0.8 percentage points, on the low side; measured number inside the range.
By their numbers in this assay, from the lowest: compound 1; then compound 3; then compound 2.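

In this assay, the change from 4-fluorophenoxy to 4-methoxyphenoxy now has a reading of its own, with the cyclopropyl group held on the aromatic nitrogen: methoxy in place of fluoro gives a number 20.2 percentage points lower from compound 2 to compound 3 (beyond the scatter). The aromatic nitrogen can also be read separately, with the methoxy group held constant: cyclopropyl in place of methyl gives a number 20.4 percentage points higher from compound 1 to compound 3 (beyond the scatter), a step of similar size to the first but in the opposite direction. No measurement available here accounts for either step.

On these data alone, each change is read only once and against one background, so it remains open whether either step keeps its size elsewhere. Also open, as far as these compounds go, is how chloro or trifluoromethoxy on the aromatic ring, or ethyl on the aromatic nitrogen, would read.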